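The source may hold more compounds than are shown below. What is called first, only, known or untested is meant among the compounds shown, and "the series" means these compounds.

Within the shared core, two compounds have been measured in an ADME assay on PANC-1 cells (Homo sapiens) for cytotoxicity, read by sulforhodamine B assay, with a stated time of 48 h, tested at 10 uM; a higher number here means more inhibition at the concentration tested (going by the name of the read-out), a lower number less inhibition. Compound 1 `COc1nc2ccc(Br)cc2cc1C(c1ccccc1)n1cc(-c2ccccc2F)nn1` gives 14.7%, and compound 2 `CCCCCCCCc1cn(C(c2ccccc2)c2cc3cc(Br)ccc3nc2OC)nn1` gives 12.1%. Compound 2 stands alongside compound 1, the gap being a number 2.6 percentage points lower from compound 1 to compound 2 (within the scatter), a step within the scatter. Compound 3 `COc1nc2ccc(Br)cc2cc1C(c1ccccc1)n1cc(CCO)nn1` follows from compound 2 by hydroxy in place of hexyl on a saturated chain carbon, two bonds along the chain from an aromatic carbon. For the measured compounds named here, no measured step covers a hydroxy for hexyl exchange; the only step known at the same position stayed within the scatter, so in this assay no movement beyond the scatter is expected. Compound 3 is expected at 10%, in a range from 0% to 25%. The expected step is a number 2.1 percentage points lower from compound 2 to compound 3 (within the scatter).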

Compound 3, a percentage reported as inhibition, at one concentration (the size of the read-out at that concentration, not a potency): 19.8%
Estimate against measurement, compound 3: 9.8 percentage points below, and the stated range covers the measured number.
By their numbers in this assay, from the lowest: compounds 2, 1 and 3 (each within the scatter of the next).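

Octyl to 2-hydroxyethyl at this position gives a number 7.7 percentage points higher from compound 2 to compound 3 (within the scatter), and replacing 2-fluorophenyl with 2-hydroxyethyl gives a number 5.1 percentage points higher from compound 1 to compound 3 (within the scatter). In this assay, the hydrogen-bond donor and acceptor that enter with hydroxy therefore bring no step beyond the scatter, and all three groups at this position stay within it. Nothing at hand accounts for these small steps.

Open, on these data alone, is whether an amine or a carboxylic acid at the end of the chain would give a step beyond the scatter. As far as these compounds go, whether any group at this position moves the number in this assay also stays open.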